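A further methyl on an amide-type nitrogen

The compounds below may be only part of what the source reports. "The series", "measured", "known", "first", "only" and "open" are said of these compounds alone.

In a physicochemical assay for lipophilicity, measured as octanol-water partition, at pH 7.4 (a higher number here means a more lipophilic compound, a lower number a more polar compound), compound 1 `Cc1ccc2[nH]c(C(=O)N[C@H]3CN(S(=O)(=O)c4ccccc4)C[C@@H]3C(=O)N[C@H]3CCCNC3)cc2c1` gives 1.3 and compound 2 `O=C(N[C@H]1CN(S(=O)(=O)c2ccccc2)C[C@@H]1C(=O)N[C@H]1CCCNC1)c1cc(-c2ccccc2Cl)on1` gives 1.9. Exchanging the group on a carbonyl carbon produces a number 0.60 log units higher from compound 1 to compound 2 (beyond the scatter), but that kind of change does not recur here. Compound 3 `CN(C(=O)c1cc(-c2ccccc2Cl)on1)[C@H]1CN(S(=O)(=O)c2ccccc2)C[C@@H]1C(=O)N[C@H]1CCCNC1`, at 1.6, lies within the scatter of both other compounds. Compound 4 `CN(C(=O)[C@H]1CN(S(=O)(=O)c2ccccc2)C[C@@H]1N(C)C(=O)c1cc(-c2ccccc2Cl)on1)[C@H]1CCCNC1` differs from it by methyl in place of hydrogen on an amide-type nitrogen. The same kind of change, made on another amide-type nitrogen, gave a number 0.30 log units lower from compound 2 to compound 3 (within the scatter), and this is the closest guide available. On that basis, the expected result is no change at the digits printed from compound 3 to compound 4 (within the scatter), with no step beyond the scatter. Compound 4 is estimated at 1.6, within an expected range from 1.2 to 2.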

Compound 4, distribution coefficient: 1.6
The estimate for compound 4 equals the measured number at the digits printed; low and high end bracket the measured number.
By their numbers in this assay, from the lowest: compounds 1, 3, 4 and 2 (each within the scatter of the next, the first and the last beyond it).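

In this assay, methyl in place of hydrogen on an amide-type nitrogen whose other neighbours are a carbonyl carbon and a saturated ring carbon gives no change at the digits printed from compound 3 to compound 4 (within the scatter) as its result. With a number 0.30 log units lower from compound 2 to compound 3 (within the scatter) on the other amide-type nitrogen, the same change has now stayed within the scatter at two places in these compounds. Nothing available explains this result. As far as these compounds go, what remains open is whether an ethyl group or a longer chain on this nitrogen would also stay within the scatter of compound 3. From the compounds shown here alone, a chain ending in an amine or a carboxylic acid is equally open.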